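Permeability of a quinoline series: dropping the dimethylamino group

The compounds below may be only part of what the source reports. "The series", "measured", "known", "first", "only" and "open" are said of these compounds alone.

Compound 1, `COc1ccc(F)cc1CNCCCNc1ccnc2cc(Cc3ccc(C#N)cc3)ccc12`: 23 10^-6 cm/s
Compound 2, `COc1ccc(F)cc1CNCCCNc1ccnc2cc(-c3cccc4ccccc34)ccc12`: 237 10^-6 cm/s
Compound 3, `COc1ccc(F)cc1CNCCCNc1ccnc2cc(Oc3cccc(N(C)C)c3)ccc12`: 317 10^-6 cm/s

In an ADME assay for permeability, using PAMPA, with a stated time of 30 min, at pH 7.4 (on this read-out lower numbers stand for lower permeability and higher numbers for higher permeability), compound 3 stands highest of the three measured compounds. Its nearest neighbour is compound 2, and that pair differs only within the scatter, as a 1.3-fold higher number from compound 2 to compound 3 (0.13 log units; within the scatter) shows. Compound 1 lies far below both: a 10-fold higher number from compound 1 to compound 2 (1.01 log units; beyond the scatter) and a 14-fold higher number from compound 1 to compound 3 (1.14 log units; beyond the scatter) are large steps.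

Compound 4, `COc1ccc(F)cc1CNCCCNc1ccnc2cc(Oc3ccccc3)ccc12`, has not yet been measured. It differs from compound 3 by hydrogen in place of dimethylamino on an aromatic carbon. Going by the values given here, none of the measured steps removes a dimethylamino group; each of them swaps the whole side group, and the only step that stays within the scatter, a 1.3-fold higher number from compound 2 to compound 3 (0.13 log units; within the scatter), involves a side group unrelated to the phenoxy. The data therefore give no direct guide, and compound 4 is expected to give a step of a 1.1-fold lower number from compound 3 to compound 4 (0.05 log units; within the scatter) in this assay, no larger than the scatter. Compound 4 is estimated at 280 10^-6 cm/s, with a range from 150 10^-6 cm/s to 500 10^-6 cm/s.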

Compound 4, apparent permeability in the ADME assay: 317 10^-6 cm/s
Compound 4: middle estimate off by 1.1-fold (0.05 log units), on the low side; measured number inside the range.
By their numbers in the ADME assay, from the lowest: compound 1; then compounds 2, 3 and 4 (each within the scatter of the next).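

Going by these compounds alone, in the ADME assay, the first step confined to this position, the meta dimethylamino group on the phenoxy ring, shows that taking it away leaves the read-out in place (no change at the digits printed from compound 3 to compound 4 (within the scatter)), so the high numbers of this pair do not depend on that group. Within the data shown here, the plain phenoxy also keeps the picture the earlier compounds gave, with a 1.3-fold higher number from compound 2 to compound 4 (0.13 log units; within the scatter) and a large 14-fold higher number from compound 1 to compound 4 (1.14 log units; beyond the scatter). In a physicochemical assay for acid dissociation, compound 3 gives 9.28 and compound 4 gives 9.28, and nothing offered here explains why the change leaves both read-outs where they stand.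

Going by these compounds, whether a carboxylic acid or a primary amine on that same aromatic carbon would also leave both read-outs in place stays open. So does whether a longer chain on the nitrogen would do so.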